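The source may hold more compounds than are shown below. What is called first, only, known or untested is meant among the compounds shown, and "the series" means these compounds.

In an ADME assay on MRC5 cells (Homo sapiens) for inhibition, read by MTT assay, with a stated time of 72 h (a higher number here means a weaker inhibitor, a lower number a stronger inhibitor), compound 1 `O=C(OCCCCCCCCO)OCCc1ccc(O)c(O)c1` gives > 50000 nM, which is a limit of the assay. Compound 2 `CCCCCCOC(=O)OCCc1ccc(O)c(O)c1` gives 11200 nM. Compound 3 `CCCCCCCCOC(=O)OCCc1ccc(O)c(O)c1` gives 37900 nM, the higher of the two actual numbers. Compound 4 `CCCCCCCCCCCCCCOC(=O)OCCc1ccc(O)c(O)c1` differs from compound 3 by hexyl in place of hydrogen on a saturated chain carbon, eight bonds along the chain from an oxygen next to a carbonyl group. Among the compounds with values here, the closest precedent is a 3.4-fold higher number from compound 2 to compound 3 (0.53 log units; beyond the scatter), with ethyl in place of hydrogen on the chain. The steps of an at least 4.4-fold lower number from compound 1 to compound 2 (0.64 log units; beyond the scatter) and an at least 1.3-fold lower number from compound 1 to compound 3 (0.12 log units; that floor lies within the scatter) start from a limit and bear less directly. One step is thin support, so only a small upward move is expected in this assay, and a limit reading would not be surprising. The expected step is a 1.5-fold higher number from compound 3 to compound 4 (0.16 log units; within the scatter). The estimate for compound 4 is 55000 nM, with an expected range of 15000 nM to 120000 nM.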

Compound 4, half-maximal inhibitory concentration: 9100 nM
Estimate against measurement, compound 4: 6.0-fold (0.78 log units) above; the measured number lies below the stated range.
By their numbers in this assay, from the lowest: compounds 4 and 2 (each within the scatter of the next); then compound 3. At a limit, above all of these: compound 1.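

In this assay a longer chain at this carbon does not keep raising the number: hexyl in place of hydrogen gives a 4.2-fold lower number from compound 3 to compound 4 (0.62 log units; beyond the scatter) and so runs against a 3.4-fold higher number from compound 2 to compound 3 (0.53 log units; beyond the scatter) on the shorter chain. With a 1.2-fold lower number from compound 2 to compound 4 (0.09 log units; within the scatter) as the remaining step, these two compounds read alike and compound 3 stands apart from both. The step of an at least 5.4-fold lower number from compound 1 to compound 4 (0.73 log units; beyond the scatter) starts from a limit: the limit of > 50000 nM in this assay, at which 1 of the 4 values shown sits.

From the compounds shown here alone, whether a chain longer than that of compound 4 holds this level stays open. So does the effect of an amine or a carboxylic acid at the chain end.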